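Adding bromo to compound 1: what to expect

This account rests on a few compounds, and the source may have more. Where it says the series, first, only, none or still open, it means among the compounds named here.

Compound 1 `O=C(Nc1cccc(Cl)c1)c1ccccc1O` was tested in an assay for inhibition of HSP60/HSP10 (Homo sapiens), with a stated time of 60 min; a higher number here means a weaker inhibitor, a lower number a stronger inhibitor. In this assay compound 1 gives only a limit, > 100000 nM. Compound 2 `COc1ccccc1C(=O)Nc1cccc(Cl)c1` differs from compound 1 by methyl in place of hydrogen on an oxygen on an aromatic ring. In this assay compound 2 also gives only a limit, > 100000 nM. The step that the two limits leave unreadable from compound 1 to compound 2 therefore cannot be read in size, since both values sit at the limit of > 100000 nM in this assay, at which 2 of the 3 values shown sit. Among the measured compounds shown here, compound 3 `O=C(Nc1ccc(Sc2nc3ccccc3s2)cc1)c1cccc(Br)c1O`, the only compound with a number rather than a limit, gives 26000 nM in this assay.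

Compound 4 `O=C(Nc1cccc(Cl)c1)c1cccc(Br)c1O` differs from compound 1 by bromo in place of hydrogen on an aromatic carbon, ortho to a hydroxy group and meta to a large group. For the measured compounds named here, no measured step bears directly on this change; the single measured step, from compound 1 to compound 2, is unreadable and concerns a different place. Compound 3 carries bromo ortho to a hydroxy group but differs from compound 4 elsewhere too, so its value only shows that a bromo-bearing compound can fall inside the measurable range. It is therefore expected that compound 4 gains somewhat in inhibition while possibly staying at the limit, the expected step being an at least 1.6-fold lower number from compound 1 to compound 4 (0.22 log units; that floor lies within the scatter). The estimate for compound 4 is 60000 nM, with a range from 15000 nM to 200000 nM.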

Compound 4, half-maximal inhibitory concentration: > 100000 nM
Compound 4: no number, only a limit; the forecaster's own chance of this, stated with the estimate: 40%; middle value at least 1.6-fold (0.22 log units) from the limit.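

Compound 1 and compound 4 both give only a limit in this assay, so the step between them cannot be read in size: the limit of > 100000 nM in this assay, at which 3 of the 4 values shown sit.

The compounds shown leave open whether bromo in place of hydrogen on an aromatic carbon changes inhibition at all in this assay when the rest of compound 1 stays the same.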